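Methoxy on the cyclohexyl ring of compound 2

The compounds below may be only part of what the source reports. "The series", "measured", "known", "first", "only" and "open" are said of these compounds alone.

Measured in an ADME assay on S9 fraction (Rattus norvegicus) for metabolic stability, with a stated time of 60 min; a higher number here means that more of the compound is left, a lower number that less of the compound is left:
- compound 1 `CC(C)(O)c1ccc(-c2cnc3c(n2)N(CCC2CCOCC2)C(=O)CN3)cn1`: 73%
- compound 2 `CC(C)(O)c1ccc(-c2cnc3c(n2)N(CC2CCCCC2)CC(=O)N3)cn1`: 16%

Compound 2 stands lowest of the two, with compound 1 higher by more than the scatter. Compound 3 `CO[C@H]1CC[C@@H](CN2CC(=O)Nc3ncc(-c4ccc(C(C)(C)O)nc4)nc32)CC1` follows from compound 2 by one change: methoxy in place of hydrogen on a saturated ring carbon, giving cyclohexylmethyl to (4-methoxycyclohexyl)methyl. For the measured compounds named here, no measured step shows this change, so the expectation is loose. A moderate rise in this assay is expected, starting from compound 2 at 16%. The expected size is a number 19 percentage points higher from compound 2 to compound 3 (beyond the scatter), probably beyond the scatter. For compound 3 the estimated value is 35%, with an expected range of 15% to 60%.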

Compound 3, percent of the compound remaining: 39%
Beside the measured number, compound 3's estimate is 4 percentage points below it; the range from low to high includes it.
By their numbers in this assay, from the lowest: compound 2; then compound 3; then compound 1.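

In this assay, for the compounds shown here, methoxy in place of hydrogen on a saturated ring carbon gives a number 23 percentage points higher from compound 2 to compound 3 (beyond the scatter), the first single-change step and the first sign that this cyclohexyl ring position can shift the read-out beyond the scatter. The step rests on one substituent at one ring carbon. Nothing at hand bears on the reason for the rise. On these data alone, whether hydroxy, fluoro or an amine on the same ring carbon would give a step of similar size stays open. Also open, as far as these compounds go, is how the opposite ring stereochemistry of the methoxy group would read.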